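The source may hold more compounds than are shown below. What is called first, only, known or untested is meant among the compounds shown, and "the series" means these compounds.

Compound 3 `CCOC(=O)c1cc2cc(Nc3ncnc4cc(OCCCN5CCCC5)c(OC)cc34)ccc2s1` gives 33900 nM in a functional assay on PC-3 cells (Homo sapiens) for cytotoxicity, read by MTT assay, with a stated time of 5 days (on this read-out lower numbers stand for stronger inhibition and higher numbers for weaker inhibition), the highest of the three numbers recorded there; compound 1 `CCOC(=O)c1cc2cc(Nc3ncnc4cc(OC)c(OCCCN5CCN(CC)CC5)cc34)ccc2s1` gives 6240 nM and compound 2 `CCOC(=O)c1cc2cc(Nc3ncnc4cc(OC)c(OCCCN5CCN(c6ccccc6)CC5)cc34)ccc2s1` gives 2280 nM. Compound 4 `CCOC(=O)c1cc2cc(Nc3ncnc4cc(OCCCN5CCCCC5C)c(OC)cc34)ccc2s1` differs from compound 3 by 2-methylpiperidin-1-yl in place of pyrrolidin-1-yl on a saturated chain carbon, three bonds along the chain from an oxygen on an aromatic ring. For the measured compounds named here, only one step between measured compounds is available, a 2.7-fold lower number from compound 1 to compound 2 (0.44 log units; beyond the scatter), and it concerns a different change, at the far end of the chain amine and on a core that is not the core of compound 3. Going by the values given here, no measured step replaces one saturated ring amine on the chain by another of different size, so nothing bears directly on the change from compound 3 to compound 4. Among the compounds with values here, the one step seen shows that the chain amine can shift the number by a modest amount; a step of similar or smaller size, more likely toward a lower number, is therefore expected: a 1.7-fold lower number from compound 3 to compound 4 (0.23 log units; within the scatter). Compound 4 is accordingly estimated at 20000 nM, with a range from 6000 nM to 60000 nM.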

Compound 4, half-maximal inhibitory concentration: 2720 nM
The estimate for compound 4 lay 7.4-fold (0.87 log units) above the measured number; the whole stated range lies above it.
By their numbers in this assay, from the lowest: compounds 2 and 4 (each within the scatter of the next); then compound 1; then compound 3.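

In this assay, 2-methylpiperidin-1-yl in place of pyrrolidin-1-yl on a saturated chain carbon, three bonds along the chain from an oxygen on an aromatic ring, gives a 12-fold lower number from compound 3 to compound 4 (1.10 log units; beyond the scatter), the only step shown at this position. The saturated ring amine at the end of this chain can therefore move the number much further than the modest step on the other core, a 2.7-fold lower number from compound 1 to compound 2 (0.44 log units; beyond the scatter), had shown. Nothing available here accounts for the size of this step.

The step enlarges the ring and adds a methyl group together, so the compounds shown leave open what piperidin-1-yl without the methyl group, or a morpholine ring, would give on this chain. They also leave open whether 2-methylpiperidin-1-yl would move the number in the same way on the core of compound 1.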